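Ethyl to isopropyl on the core of compound 2

This account rests on a few compounds, and the source may have more. Where it says the series, first, only, none or still open, it means among the compounds named here.

Measured compounds:
- compound 1, `O=C(Nc1cc(C(F)(F)F)cc(C(F)(F)F)c1)NN1CCOCC1`: 5 ug/mL
- compound 2, `CCc1nc2ccccc2c(=O)n1NC(=O)Nc1cc(C(F)(F)F)cc(C(F)(F)F)c1`: 59 ug/mL

In a physicochemical assay for solubility, at pH 7.4 (a lower number here means a less soluble compound, a higher number a more soluble compound), compound 2 gives 59 ug/mL, the higher of the two numbers shown. Its nearest neighbour is compound 1, which in this assay gives 5 ug/mL, a gap that lies beyond the scatter. The two structures share the bis(trifluoromethyl)phenyl urea but differ in more than one place, so only their two values can be set side by side.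

Compound 3, `CC(C)c1nc2ccccc2c(=O)n1NC(=O)Nc1cc(C(F)(F)F)cc(C(F)(F)F)c1`, has not yet been measured. It differs from compound 2 in one place: methyl in place of hydrogen on a saturated chain carbon bound to an aromatic carbon and a saturated chain carbon. For the measured compounds named here, no step between measured compounds bears on this change, so the expectation rests on the change itself and on the value of compound 2. Adding one carbon to a saturated chain would be expected to give a modest drop in this assay, of a size near the edge of the scatter, and the expected step is a 1.7-fold lower number from compound 2 to compound 3 (0.23 log units; within the scatter). For compound 3 in this assay the estimate is 35 ug/mL, with a range from 12 ug/mL to 90 ug/mL.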

Compound 3, solubility: 3 ug/mL
Compound 3: middle estimate off by 12-fold (1.07 log units), on the high side, outside the stated range (below it).
By their numbers in this assay, from the lowest: compounds 3 and 1 (each within the scatter of the next); then compound 2.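

In this assay, the two earlier compounds could only be set side by side, as they differ in more than one place. Compound 3 gives the first single-place reading: methyl in place of hydrogen on a saturated chain carbon bound to an aromatic carbon and a saturated chain carbon, the change from ethyl to isopropyl, comes with a 20-fold lower number from compound 2 to compound 3 (1.29 log units; beyond the scatter). This shows that at this position a change of one carbon, with no ring, no hydrogen-bond donor or acceptor and no net charge entering, can carry a large step rather than a modest one. Nothing among the data shown bears on what lies behind a step of this size.

On these data alone, it remains open whether the step follows the added carbon as such or the branch at this carbon, a question that an unbranched propyl chain at the same place would address. Also open, as far as these compounds go, is how the read-out would respond to a cyclopropyl ring, or to a chain ending in a hydroxyl group or an amine, at this position.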